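One chain stereocentre changed in compound 3

This account rests on a few compounds, and the source may have more. Where it says the series, first, only, none or still open, it means among the compounds named here.

Measured in an ADME assay on microsomes (Mus musculus) for metabolic stability, with a stated time of 1 h, tested at 1 uM; a lower number here means that less of the compound is left, a higher number that more of the compound is left:
- compound 1 `C[C@H](CO)N1C[C@H](C)[C@@H](CN(C)Cc2ccc(Oc3ccccc3)cc2)Oc2c(NC(=O)c3ccncc3)cccc2C1=O`: 70%
- compound 2 `C[C@@H]1CN([C@H](C)CO)C(=O)c2cccc(NC(=O)c3ccncc3)c2O[C@@H]1CN(C)Cc1ccc(Oc2ccccc2)cc1`: < 1% (a limit of the assay)
- compound 3 `C[C@@H]1CN([C@H](C)CO)C(=O)c2cccc(NC(=O)c3ccncc3)c2O[C@H]1CN(C)Cc1ccc(Oc2ccccc2)cc1`: 1%

These three compounds share the same atoms and bonds, yet they part widely in this assay. Compound 3, at 1%, has the lower of the two actual numbers, far under compound 1 at 70%. Compound 2 gives < 1%, which is a limit and not a number.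

The next compound is compound 4 `C[C@@H]1CN([C@@H](C)CO)C(=O)c2cccc(NC(=O)c3ccncc3)c2O[C@H]1CN(C)Cc1ccc(Oc2ccccc2)cc1`, and its change from compound 3 is purely one of spatial arrangement: the two compounds have the same atoms and bonds and differ only in configuration as drawn: 1 of 3 stereo elements differ; a stereocentre at a saturated chain carbon is drawn R in compound 3 and S in compound 4.

Two measured steps show how much configuration can matter: a number at least 69 percentage points lower from compound 1 to compound 2 (beyond the scatter), and a number 69 percentage points lower from compound 1 to compound 3 (beyond the scatter). The third, a number no lower from compound 2 to compound 3 (the limit leaves the size open), has no readable size. All three steps involve stereocentres at saturated ring carbons, so none tests the chain carbon directly.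

Compound 4 keeps the ring configuration of compound 3, which gives 1%, so a low value is the likeliest outcome. A large rise remains possible, since a configuration change alone produced a number 69 percentage points lower from compound 1 to compound 3 (beyond the scatter). The expected step, with no change beyond the scatter as the likeliest result, is a number 7 percentage points higher from compound 3 to compound 4 (within the scatter). The estimate for compound 4 is 8%, with an expected range from 1% to 45%.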

Compound 4, percent of the compound remaining: 2%
For compound 4 the middle estimate is 6 percentage points above the measured one; low and high end bracket the measured number.
By their numbers in this assay, from the lowest: compounds 3 and 4 (each within the scatter of the next); then compound 1.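

In this assay, among these compounds, inverting the saturated chain carbon gives a number 1 percentage points higher from compound 3 to compound 4 (within the scatter), and this is the first step to test that stereocentre directly: with the ring carbons drawn as in compound 3, this inversion moves the number by no more than the scatter. Going by these compounds, compound 4 is the mirror image of compound 1, yet the gap between these two same-atom compounds is large, with a number 68 percentage points lower from compound 1 to compound 4 (beyond the scatter), so the chain carbon joins the ring carbons in a set of three inversions that together separate a well-retained compound from a poorly retained one: the fact that compounds 1 and 4 differ only in the configuration as drawn The remaining step, a number at least 1 percentage points higher from compound 2 to compound 4 (that floor lies within the scatter), starts from a limit, so its true size stays open.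

The compounds shown leave open whether the chain carbon matters when the two ring carbons are drawn as in compound 1, the only compound here with a high number, since the single inversion at the chain carbon is seen only with the ring carbons of compound 3. They also leave open what happens in this assay if the hydroxyl on that chain gives way to an amine, a carboxylic acid or a longer chain.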